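Methylamino in place of methoxy on the shared core

A few compounds are considered here, and "the series" means these few. Any claim that something is new, unique, unknown or untested is made for them only; others in the source may bear on it.

Of the compounds shown here, three have been measured. In a functional assay on CCRF-CEM cells (Homo sapiens), read by MTT assay, with a stated time of 3 days (a lower number here means a stronger inhibitor, a higher number a weaker inhibitor), compound 1 `COc1ncnc2[nH]cc(Sc3cccs3)c12` gives 18200 nM, compound 2 `CN(C)c1ncnc2[nH]cc(Sc3cccs3)c12` gives 14600 nM, and compound 3 `c1coc(-c2ncnc3[nH]cc(Sc4cccs4)c23)c1` gives 7730 nM. Compound 1 therefore carries the highest number of the three: the step of a 1.2-fold lower number from compound 1 to compound 2 (0.10 log units; within the scatter) stays within the scatter, while a 2.4-fold lower number from compound 1 to compound 3 (0.37 log units; beyond the scatter) lies beyond it, and a 1.9-fold lower number from compound 2 to compound 3 (0.28 log units; within the scatter) is again within the scatter.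

Compound 4 `CNc1ncnc2[nH]cc(Sc3cccs3)c12` differs from compound 1 as follows: methylamino in place of methoxy on an aromatic carbon. The step that bears on this change is a 1.2-fold lower number from compound 1 to compound 2 (0.10 log units; within the scatter), since it also replaces methoxy with an amino group at the same position and gave no shift beyond the scatter. The furan-2-yl step a 2.4-fold lower number from compound 1 to compound 3 (0.37 log units; beyond the scatter) is of a different kind and is set aside. In this assay compound 4 is therefore expected to sit near compound 1, the expected step being a 1.3-fold lower number from compound 1 to compound 4 (0.11 log units; within the scatter). The estimate for compound 4 is 14000 nM, with a range from 6000 nM to 32000 nM.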

Compound 4, half-maximal inhibitory concentration: 14700 nM
Compound 4: middle estimate off by 1.1-fold (0.02 log units), on the low side; the range from low to high includes it.
By their numbers in this assay, from the lowest: compounds 3, 2, 4 and 1 (each within the scatter of the next, the first and the last beyond it).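

In this assay, the methylamino group brings a hydrogen-bond donor that methoxy lacks, yet a 1.2-fold lower number from compound 1 to compound 4 (0.09 log units; within the scatter) shows that this exchange does not separate the two groups at this position. Hydrogen in place of methyl on the nitrogen gives a 1.0-fold higher number from compound 2 to compound 4 (0.00 log units; within the scatter) and so adds no separation either. Methylamino and furan-2-yl also remain unresolved, with a 1.9-fold higher number from compound 3 to compound 4 (0.28 log units; within the scatter) as the step between them.

From the compounds shown here alone, whether an unsubstituted amino group or a longer chain such as ethylamino would depart from these values remains open. No measured evidence bears on these results.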